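This account rests on a few compounds, and the source may have more. Where it says the series, first, only, none or still open, it means among the compounds named here.

Values measured in a functional assay on MCF7 cells (Homo sapiens) for antiproliferative activity, read by MTT assay, with a stated time of 24 h (on this read-out higher numbers stand for weaker inhibition and lower numbers for stronger inhibition), are these:

- Compound 1 `Cc1ccc(-c2nn(-c3ccccc3)cc2-c2nc3ccccc3[nH]2)cc1` gives 7260 nM
- Compound 2 `Cc1ccc(-c2nn(-c3ccccc3)cc2-c2nc3ccccc3n2S(=O)(=O)c2ccccc2)cc1` gives 830 nM
- Compound 3 `O=S(=O)(c1ccccc1)n1c(-c2cn(-c3ccccc3)nc2-c2ccc(F)cc2)nc2ccccc21` gives 690 nM

Compound 3 at 690 nM stands within the scatter of compound 2 and has a clearly lower number than compound 1. The next compound, compound 4 `O=S(=O)(c1ccc(Cl)cc1)n1c(-c2cn(-c3ccccc3)nc2-c2ccc(F)cc2)nc2ccccc21`, carries chloro in place of hydrogen on an aromatic carbon, which turns phenylsulfonyl into (4-chlorophenyl)sulfonyl chloro in place of hydrogen on an aromatic carbon and leaves the rest of compound 3 unchanged.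

Among the measured compounds shown here, two measured steps bear on this change. Phenylsulfonyl in place of hydrogen on an aromatic nitrogen gave an 8.7-fold lower number from compound 1 to compound 2 (0.94 log units; beyond the scatter), but that step added the whole group, whereas the new change replaces a single hydrogen on it. Fluoro in place of methyl on an aromatic carbon gave a 1.2-fold lower number from compound 2 to compound 3 (0.08 log units; within the scatter), and this is the only measured exchange of one small substituent, although it lies elsewhere in the molecule. For the measured compounds named here, no measured compound varies the phenylsulfonyl ring itself, so the direction remains open and any expectation is loose.

A small change is therefore expected in this assay, with the estimated 1.2-fold lower number from compound 3 to compound 4 (0.06 log units; within the scatter) not exceeding the scatter. For compound 4 the estimate is 600 nM, with an expected range from 220 nM to 1500 nM.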

Compound 4, half-maximal inhibitory concentration: 4960 nM
Beside the measured number, compound 4's estimate is 8.3-fold (0.92 log units) below it; measured number outside the range, above it.
By their numbers in this assay, from the lowest: compounds 3 and 2 (each within the scatter of the next); then compounds 4 and 1 (each within the scatter of the next).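

In this assay, among the compounds shown here, the addition of chloro to the phenylsulfonyl ring, para to a large group, gave a 7.2-fold higher number from compound 3 to compound 4 (0.86 log units; beyond the scatter) and so shows that this ring, constant in the earlier compounds, does not tolerate every change: one added heavy atom here moved the number beyond the scatter. For the compounds shown here, the only earlier exchange of one small substituent, fluoro in place of methyl at another place in the molecule, gave a 1.2-fold lower number from compound 2 to compound 3 (0.08 log units; within the scatter) and stayed within the scatter, so the two places differ in how far a single small change moved the number in these compounds. The data shown give no measured basis for explaining this rise.

As far as these compounds go, whether the rise belongs to chloro in particular or would also follow from another group at this place, such as methoxy or an amine, remains open. From the compounds shown here alone, it is also open whether the same chloro change would give a step of similar size in the methyl-bearing compound 2, or whether a group placed elsewhere on this ring would behave alike.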